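Swapping a Methyl for a Hydroxy Group: Expected Solubility

The compounds below may be only part of what the source reports. "The series", "measured", "known", "first", "only" and "open" are said of these compounds alone.

Measured compounds:
compound 1, `Cc1cc(NC(=O)Nc2ccc(C)c(Cl)c2)c2ccccc2n1`, 300 nM
compound 2, `Cc1cc(NC(=O)Nc2cc(F)ccc2F)c2ccccc2n1`, 500 nM
compound 3, `Cc1ccc(NC(=O)Nc2cc(C)nc3ccccc23)cc1`, 1300 nM

These three compounds, which share one core, were measured in a physicochemical assay for solubility, at pH 7.4; a lower number here means a less soluble compound, a higher number a more soluble compound. Compound 3 stands highest of the three: its number lies beyond the scatter above compound 2 and further beyond the scatter above compound 1. Among the compounds with values here, only one pair of measured compounds differs in a single place, and that step, a 4.3-fold higher number from compound 1 to compound 3 (0.64 log units; beyond the scatter), shows a modest rise when a chloro is removed.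

Compound 4 `Cc1cc(NC(=O)Nc2ccc(O)cc2)c2ccccc2n1` has not yet been measured. It differs from compound 3 by hydroxy in place of methyl on an aromatic carbon. Within the data shown here, no measured step makes this same exchange; the one step available, a 4.3-fold higher number from compound 1 to compound 3 (0.64 log units; beyond the scatter), concerns a different group, so it offers at most a loose hint that exchanging one substituent on the outer aromatic ring can shift the number modestly. A small to modest increase in this assay is therefore expected, although a result within the scatter of compound 3 would not be surprising. For compound 4 the expected value is 2500 nM, with a range from 1000 nM to 6500 nM. That estimate means an expected step of a 1.9-fold higher number from compound 3 to compound 4 (0.28 log units; within the scatter).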

Compound 4, solubility: 100 nM
Compound 4: the middle estimate sits 25-fold (1.40 log units) above what was measured; measured number outside the range, below it.
By their numbers in this assay, from the lowest: compound 4; then compounds 1 and 2 (each within the scatter of the next); then compound 3.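

In this assay, the change from 4-methylphenyl to 4-hydroxyphenyl brings a large fall (a 13-fold lower number from compound 3 to compound 4 (1.11 log units; beyond the scatter)), so the group on this aromatic carbon, para to a large group, matters a great deal even though one heavy atom simply replaces another. Within the data shown here, the only earlier single-place step, the removal of a chloro (a 4.3-fold higher number from compound 1 to compound 3 (0.64 log units; beyond the scatter)), was a modest rise, so these compounds now show that a one-atom exchange on this ring can move the number down as well as up, and by more. The exchange adds one hydrogen-bond donor and one hydrogen-bond acceptor, but nothing measured here ties the fall to those counts or to any other cause.

The compounds shown leave open whether the fall belongs to hydroxy alone, or whether an amine, a methoxy or a carboxylic acid at the same place would give a similar number. They also leave open whether the same exchange from methyl to hydroxy would have a similar effect with a chloro kept on the ring, as in compound 1.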